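This account rests on a few compounds, and the source may have more. Where it says the series, first, only, none or still open, it means among the compounds named here.

Measured so far:
- Compound 1 `CCc1c(C)[nH]c2cc(OC)c(Cl)cc2c1=O`: 19000 nM
- Compound 2 `CCc1c(C)[nH]c2cc(OC)c(Br)cc2c1=O`: > 33900 nM (a limit of the assay, not a number)

Going by the values given here, in an ADME assay on J774 cells (Mus musculus) for cytotoxicity (a lower number here means that less compound is needed, a higher number that more compound is needed for the effect), compound 1 gives 19000 nM, the only true number available so far. Compound 2 gives only a limit, > 33900 nM. No ranking of compound 1 can therefore be drawn beyond this single comparison.

Compound 3 `COc1cc2[nH]c(C)c(C3CCCCC3)c(=O)c2cc1Cl` keeps the core of compound 1 and changes one group: cyclohexyl in place of ethyl on an aromatic carbon. That is cyclohexyl in place of ethyl on an aromatic carbon, a clearly larger group.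

Among the compounds with values here, only one measured step exists, an at least 1.7-fold higher number from compound 1 to compound 2 (0.25 log units; that floor lies within the scatter). It swaps bromo for chloro and leaves the ethyl group untouched, so it bears only weakly on this change. Within the data shown here, no measured step shows what replacing ethyl does here. The best guide is therefore the value of compound 1, 19000 nM, with a wide margin in either direction.

In this assay the expected change is a 1.3-fold lower number from compound 1 to compound 3 (0.10 log units; within the scatter), which means no step beyond the scatter is expected. For compound 3 the estimated value is 15000 nM, with an expected range of 5000 nM to 40000 nM.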

Compound 3, half-maximal effective concentration: > 32700 nM
Compound 3 was reported as a limit; the forecaster's own chance of this, stated with the estimate: 25%; middle value at least 2.1-fold (0.33 log units) from the limit.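

In this assay, cyclohexyl in place of ethyl on this aromatic carbon, ortho to a methyl group, gives an at least 1.7-fold higher number from compound 1 to compound 3 (0.23 log units; that floor lies within the scatter). Going by these compounds alone, this is the first look at a change at this place, and it shows that a group with one six-membered non-aromatic ring of carbon only, in place of a short ethyl group, gives no sign of a lower number than the one for compound 1; the printed floor of the step lies within the scatter, so a true rise is not established either. The reading for compound 3 is a limit of the assay and not a number: the limit of > 32700 nM in this assay, at which 1 of the 3 values shown sits.

From the compounds shown here alone, how far the true value of compound 3 lies from that of compound 1 stays open, so the full size of this step is unknown. Also open, going by these compounds, is how the number would respond at this place to a group of another kind, such as a propyl chain, a phenyl ring or an amine, and whether any such group would bring the number down.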